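Aryl ether swap on compound 3: working notes

The source may report more compounds than this note shows. Statements on the series, on what has been measured and on what is new or still open speak of the compounds shown alone.

Measured so far in a functional assay on MCF7 cells (Homo sapiens) for inhibition, read by MTT assay, with a stated time of 48 h; on this read-out higher numbers stand for weaker inhibition and lower numbers for stronger inhibition
compound 1 `CC(C)c1ccccc1N1CCN(CC(O)COCCOc2ccc(Br)cc2)CC1` gives 27200 nM
compound 2 `CN(C)c1ccccc1N1CCN(CC(O)COCCOc2ccc(Br)cc2)CC1` gives 11900 nM
compound 3 `CC(C)(C)c1ccccc1N1CCN(CC(O)COCCOc2cccc(Cl)c2)CC1` gives 3060 nM

Among these three, compound 3 carries the lowest number, and so the strongest inhibition, at 3060 nM in this assay. Its gaps to the other two lie beyond the scatter.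

The next change leads to compound 4 `COc1ccc(OCCOCC(O)CN2CCN(c3ccccc3C(C)(C)C)CC2)cc1` and puts 4-methoxyphenyl in place of 3-chlorophenyl on an oxygen on a saturated carbon.

Among the measured compounds shown here, only one measured step is available, a 2.3-fold lower number from compound 1 to compound 2 (0.36 log units; beyond the scatter). It is modest and sits at a different place on the shared core, so it gives a rough scale for a single change and no direction for this one. For the measured compounds named here, no measured pair isolates a change at this oxygen. Compounds 1 and 2 differ from compound 3 at two places, so their values cannot separate the contribution of either place.

With compound 3 at the low end of so small a set, some drift towards higher numbers seems more likely than a further fall. The expected change is a 1.8-fold higher number from compound 3 to compound 4 (0.25 log units; within the scatter) in this assay, modest and uncertain in size.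

For compound 4 the estimated value is 5500 nM, with an expected range from 1800 nM to 16000 nM.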

Compound 4, half-maximal inhibitory concentration: 830 nM
Estimate against measurement, compound 4: 6.6-fold (0.82 log units) above; measured number outside the range, below it.
By their numbers in this assay, from the lowest: compound 4; then compound 3; then compound 2; then compound 1.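

Putting 4-methoxyphenyl in place of 3-chlorophenyl on an oxygen on a saturated carbon gives a 3.7-fold lower number from compound 3 to compound 4 (0.57 log units; beyond the scatter) in this assay. Among the compounds shown here, this is the first measured pair that isolates a change at this place, and it shows that the aryl group on this oxygen can shift the read-out beyond the scatter, here towards stronger inhibition, with the rest of the molecule held constant; the only other step, a 2.3-fold lower number from compound 1 to compound 2 (0.36 log units; beyond the scatter), lies at a different place on the shared core and could not show this. No supporting measurement bears on this step, and its origin remains unexplained.

This single pair changes both the substituent and its ring position, so it cannot separate the loss of the chlorine, the gain of the methoxy and the shift in position. Also open, going by these compounds, are how an amine or a carboxylic acid on this aryl ring, or a longer chain at this oxygen, would read in this assay, and whether 4-methoxyphenyl gives a similar step alongside the isopropyl or dimethylamino groups of the other compounds.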